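Replacing the Fluorophenyl Group with Pyrimidinyl on the Piperazine Ring

The source may hold more compounds than are shown below. What is called first, only, known or untested is meant among the compounds shown, and "the series" means these compounds.

Compound 2 `Fc1ccccc1N1CCN(Cc2nc3ccccc3[nH]2)CC1` gives 42% in an assay on HEK293 cells with D(4) dopamine receptor (Homo sapiens) as the target, read by FLIPR (a higher number here means a larger maximal response, a lower number a smaller maximal response), the lower of the two numbers seen so far, with compound 1 `N#Cc1ccccc1N1CCN(Cc2nc3ccccc3[nH]2)CC1` at 46%; the difference of a number 4 percentage points lower from compound 1 to compound 2 (within the scatter) is within the scatter. Compound 3 `c1cnc(N2CCN(Cc3nc4ccccc4[nH]3)CC2)nc1` differs from compound 2 by pyrimidin-2-yl in place of 2-fluorophenyl on an amine nitrogen in a ring. Among the measured compounds shown here, the only measured step, exchanging one small substituent for another on the phenyl ring, stayed within the scatter, and no step exchanges the whole ring, so it bears little on this change. Compound 3 is therefore expected to give roughly 40%, between 20% and 62%, a step of a number 2 percentage points lower from compound 2 to compound 3 (within the scatter).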

Compound 3, largest response reached (reported as efficacy), in percent of the reference or control that the assay uses: 49%
Compound 3: middle estimate off by 9 percentage points, on the low side, within the range that was stated.
By their numbers in this assay, from the lowest: compounds 2, 1 and 3 (each within the scatter of the next).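

In this assay the steps of a number 7 percentage points higher from compound 2 to compound 3 (within the scatter) and a number 3 percentage points higher from compound 1 to compound 3 (within the scatter) both exchange a whole ring rather than a small substituent on it. On this amine nitrogen in a ring, then, pyrimidin-2-yl, with its 2 hydrogen-bond acceptors, gives a maximal response that cannot be told apart from those given by the two substituted phenyl rings. No measured evidence is available to explain this result. Still open, as far as these compounds go, is whether a non-aromatic group on this nitrogen, such as cyclohexyl or a plain methyl, would give a similar response.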